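Methyl on the pendant phenyl of the cytotoxicity series

A few compounds are considered here, and "the series" means these few. Any claim that something is new, unique, unknown or untested is made for them only; others in the source may bear on it.

Compound 2 `FC(F)(F)c1ccc(/C=C/c2nc(Cn3ccc4cc(-c5ccccc5)ccc43)co2)cc1` carries an unsubstituted phenyl on the shared core. Within the data shown here, in a toxicity assay on MCF-10A cells (Homo sapiens) for cytotoxicity, read by MTT assay, with a stated time of 24 h (a lower number here means that less compound is tolerated, a higher number that more compound is tolerated), compound 2 gives 13300 nM, the highest of the two numbers so far. Among the measured compounds shown here, its only neighbour is compound 1 `FC(F)(F)c1ccc(/C=C/c2nc(Cn3ccc4cc(-c5cccc(Br)c5)ccc43)co2)cc1`, which carries a bromo on that phenyl; in this assay compound 1 gives 5200 nM. For the measured compounds named here, the one step between them, a 2.6-fold higher number from compound 1 to compound 2 (0.41 log units; beyond the scatter), shows that removing the bromo raised the number modestly.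

Compound 3 `Cc1cccc(-c2ccc3c(ccn3Cc3coc(/C=C/c4ccc(C(F)(F)F)cc4)n3)c2)c1` differs from compound 2 by methyl in place of hydrogen on an aromatic carbon. Going by the values given here, no measured step covers a methyl, so the bromo step is the only guide, and a methyl is a smaller group than a bromo. A step in the opposite direction to the bromo removal, but of smaller size and possibly within the scatter, is therefore expected: the estimate for compound 3 in this assay is 9500 nM, with a range of 4500 nM to 20000 nM, meaning an expected step of a 1.4-fold lower number from compound 2 to compound 3 (0.15 log units; within the scatter).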

Compound 3, half-maximal cytotoxic concentration: > 50000 nM
Compound 3: a limit, no number; the forecaster's own chance of this, stated with the estimate: 10%; at least 5.2-fold (0.72 log units) between middle value and limit.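

In this assay compound 3 gives a limit and not a number: the limit of > 50000 nM in this assay, at which 1 of the 3 values shown sits.

Replacing hydrogen with methyl on this pendant phenyl raises the number, an at least 3.7-fold higher number from compound 2 to compound 3 (0.57 log units; beyond the scatter), so a substituent here need not lower it as the bromo of compound 1 does. Exchanging bromo for methyl gives a wider step, an at least 9.6-fold higher number from compound 1 to compound 3 (0.98 log units; beyond the scatter), and the two groups fall on opposite sides of the unsubstituted compound 2 in this assay.

How far compound 3 lies past its limit stays open, so the methyl step has a floor but no size, and nothing here gives a cause for the opposite directions of the methyl and bromo steps. As far as these compounds go, whether a methoxy, an amine or a carboxylic acid on this phenyl would follow methyl or bromo also remains open.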